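A few compounds are considered here, and "the series" means these few. Any claim that something is new, unique, unknown or untested is made for them only; others in the source may bear on it.

Of the compounds shown here, three carry antiproliferative numbers so far. In a functional assay on MCF7 cells (Homo sapiens) for antiproliferative activity (a lower number here means a stronger inhibitor, a higher number a weaker inhibitor), compound 1 `C#CCCn1c(Cc2cc(OC)c(OC)c(OC)c2)nc2c(N)nc(F)nc21` gives 25100 nM. Compound 3 `CCCCn1c(Cc2cc(OC)c(OC)c(OC)c2Br)nc2c(N)ncnc21` gives 25100 nM in this assay, level with compound 1 at the digits shown, and compound 2 `COc1cc(Cc2nc3c(N)ncnc3n2CC2CCC2)cc(OC)c1OC` gives 45700 nM in this assay; the gap from compound 1 to compound 2 stays within the scatter, so the three numbers are not separated from one another. Compound 4 `COCCn1c(Cc2cc(OC)c(OC)c(OC)c2)nc2c(N)nc(F)nc21` is not yet measured. It differs from compound 1 by methoxy in place of ethynyl on a saturated chain carbon, two bonds along the chain from an aromatic nitrogen. Among the compounds with values here, no measured pair isolates a change of this kind, so there is no step to lean on. For compound 4 in this assay no step beyond the scatter is expected in either direction, the estimate being 30000 nM with a range from 12000 nM to 75000 nM. The expected step is then a 1.2-fold higher number from compound 1 to compound 4 (0.08 log units; within the scatter), flat within the scatter.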

Compound 4, half-maximal inhibitory concentration: 64600 nM
Estimate against measurement, compound 4: 2.2-fold (0.33 log units) below, within the range that was stated.
By their numbers in this assay, from the lowest: compounds 1, 3, 2 and 4 (each within the scatter of the next, the first and the last beyond it).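

Within the data shown here, on the saturated chain carbon, two bonds along the chain from an aromatic nitrogen, methoxy in place of ethynyl gives a 2.6-fold higher number from compound 1 to compound 4 (0.41 log units; beyond the scatter) in this assay, the only step so far that can be read. The end of this chain therefore has a modest hold on the antiproliferative number, with the rest of compound 1 unchanged. Nothing on hand gives a reason for the step. Going by these compounds, whether a hydroxyl, an amine or a longer chain at this place would move the number further remains open. So does whether the same change carries over to a compound with a different core substitution.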